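A few compounds are considered here, and "the series" means these few. Any claim that something is new, unique, unknown or untested is made for them only; others in the source may bear on it.

Notes on the sulfonamide series. Of the compounds shown here, two have been measured in a functional assay on MIA PaCa-2 cells (Homo sapiens) for inhibition, read by MTT assay, with a stated time of 72 h; a lower number here means a stronger inhibitor of growth, a higher number a weaker inhibitor of growth. Compound 1 `O=S(=O)(NCCCNCc1cccc2ccccc12)c1cc(C(F)(F)F)cc(C(F)(F)F)c1` gives 2800 nM in this assay, the lowest of the two numbers, and compound 2 `O=S(=O)(NCCCCCCNCc1ccc(Br)cc1)c1ccccc1F` gives 13300 nM, a gap beyond the scatter; the two differ in several places at once, so no single step can be read from them. The next compound, compound 3 `O=S(=O)(NCCCNCc1ccccc1)c1cc(C(F)(F)F)cc(C(F)(F)F)c1`, differs from compound 1 in one place only: phenyl in place of naphthalen-1-yl on a saturated chain carbon bound to an amine nitrogen. Among the compounds with values here, with phenyl in place of naphthalen-1-yl on a saturated chain carbon bound to an amine nitrogen, and no measured pair showing that change, only an expectation can be written. The expected step from compound 1 to compound 3 in this assay is a modest rise, a 2.3-fold higher number from compound 1 to compound 3 (0.37 log units; beyond the scatter), somewhat beyond the scatter. For compound 3 the estimated value in this assay is 6500 nM, within a range of 2200 nM to 20000 nM.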

Compound 3, concentration for 50% growth inhibition: 11000 nM
The estimate for compound 3 lay 1.7-fold (0.23 log units) below the measured number; low and high end bracket the measured number.
By their numbers in this assay, from the lowest: compound 1; then compounds 3 and 2 (each within the scatter of the next).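

Within the data shown here, measured in this assay the change from (naphthalen-1-yl)methyl to benzyl gives a 3.9-fold higher number from compound 1 to compound 3 (0.59 log units; beyond the scatter) and is the first single-place step. It shows that this position, on a saturated chain carbon bound to an amine nitrogen, is not indifferent to the group it carries: with the rest of compound 1 unchanged, naphthalen-1-yl with its 2 six-membered aromatic rings goes with the lower number, and phenyl with one such ring goes with the higher number. Nothing at hand bears on why the step has this direction or size.

As far as these compounds go, whether the position needs an aromatic ring at all remains open, as a cyclohexyl or pyridinyl group in the same place would show. Also open, from the compounds shown here alone, is whether the same step holds on a longer chain or with other groups on the sulfonyl ring.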